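A few compounds are considered here, and "the series" means these few. Any claim that something is new, unique, unknown or untested is made for them only; others in the source may bear on it.

Measured in an ADME assay on Vero cells (Chlorocebus sabaeus) for cytotoxicity, with a stated time of 5 days; a lower number here means a stronger inhibitor, a higher number a weaker inhibitor:
- Compound 1 `COc1nc(NC2CC2)c2ncn([C@H]3C[C@H](N=[N+]=[N-])[C@@H](CO)O3)c2n1`: > 100000 nM (a limit)
- Compound 2 `C=CCNc1nc(N)nc2c1ncn2[C@H]1C[C@H](N=[N+]=[N-])[C@@H](CO)O1`: > 100000 nM (a limit)
- Compound 3 `CN(C)c1nc(N)nc2c1ncn2[C@H]1C[C@H](N=[N+]=[N-])[C@@H](CO)O1`: > 100000 nM (a limit)

Compound 3 gives > 100000 nM in this assay, which is a limit of the assay and not a number. It has no position of its own among the measured compounds, since all of them share one reading: the limit of > 100000 nM in this assay, at which 3 of the 3 values shown sit.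

Compound 4 `[N-]=[N+]=N[C@H]1C[C@H](n2cnc3c(NC4CC4)nc(N)nc32)O[C@@H]1CO` differs from compound 3 at one place: cyclopropylamino in place of dimethylamino on an aromatic carbon. The change lies on an aromatic carbon of a six-membered aromatic ring with 2 nitrogen, and the entering group brings one three-membered non-aromatic ring of carbon only.

Among the compounds with values here, only one measured step involves a change of this group on an aromatic carbon, a step that the two limits leave unreadable from compound 2 to compound 3, and it gives no size to carry over. Compound 1 also carries cyclopropylamino, and compound 1 gives > 100000 nM, again a limit. With no readable step and this one reading, no step beyond the scatter is expected in this assay. The expected step is a number no higher from compound 3 to compound 4 (the limit leaves the size open). For compound 4 the estimate is 100000 nM, with an expected range from 30000 nM to 150000 nM, and the assay may well report only a limit.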

Compound 4, half-maximal inhibitory concentration: > 100000 nM
Compound 4 gave a limit, no number (the forecaster's own chance of this, stated with the estimate: 80%); the middle value sits exactly at the limit.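

In this assay compound 4 gives > 100000 nM, which is a limit and not a number. No step between compound 4 and compound 1, compound 2 or compound 3 can be read, because all four share one reading: the limit of > 100000 nM in this assay, at which 4 of the 4 values shown sit.

The compounds shown leave open where any of the four values actually lies, and whether cyclopropylamino, dimethylamino and allylamino differ at all.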